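Heteroaryl exchange at the cyano-adjacent position of the core

A few compounds are considered here, and "the series" means these few. Any claim that something is new, unique, unknown or untested is made for them only; others in the source may bear on it.

The series shares one core, seen in compound 1 `COc1nc(-c2cc3ccccc3o2)cc(-c2ccccc2)c1C#N`, compound 2 `COc1nc(-c2cc3ccccc3o2)cc(-c2ccc(Cl)cc2)c1C#N` and compound 3 `COc1nc(-c2cc3ccccc3o2)cc(-c2ccc(N(C)C)cc2)c1C#N`. In a functional assay on aorta (strain Wistar) for inhibition, with Thoracic aorta (Rattus norvegicus) as the target (on this read-out lower numbers stand for stronger inhibition and higher numbers for weaker inhibition), compound 1 gives 232000 nM, compound 2 gives 286000 nM and compound 3 gives 278000 nM. Compound 3 stands second highest of the three numbers, yet all gaps are within the scatter: a 1.2-fold higher number from compound 1 to compound 2 (0.09 log units; within the scatter), a 1.2-fold higher number from compound 1 to compound 3 (0.08 log units; within the scatter) and a 1.0-fold lower number from compound 2 to compound 3 (0.01 log units; within the scatter).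

Compound 4 `COc1nc(-c2cc3ccccc3o2)cc(-c2ccc(C)o2)c1C#N` differs from compound 3 by 5-methylfuran-2-yl in place of 4-(dimethylamino)phenyl on an aromatic carbon. The three measured steps only vary the substituent on the aromatic ring that now leaves entirely, and none of them moved the number beyond the scatter. Going by the values given here, no measured step exchanges one aromatic ring for another, so the present change has no direct precedent. On this basis no step beyond the scatter is expected in this assay in either direction, with a wider uncertainty than the measured steps carry.

For compound 4 the expected value is 270000 nM, with a range from 120000 nM to 600000 nM. The expected step is a 1.0-fold lower number from compound 3 to compound 4 (0.01 log units; within the scatter).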

Compound 4, half-maximal inhibitory concentration: 285000 nM
The estimate for compound 4 lay 1.1-fold (0.02 log units) below the measured number, and the stated range covers the measured number.
By their numbers in this assay, from the lowest: compounds 1, 3, 4 and 2 (each within the scatter of the next).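

In this assay, exchanging the six-membered aromatic carbon ring for a five-membered aromatic ring with 1 hetero atom, at the place ortho to the cyano group and opposite the ring nitrogen, stays within the scatter: a 1.0-fold higher number from compound 3 to compound 4 (0.01 log units; within the scatter), a 1.0-fold lower number from compound 2 to compound 4 (0.00 log units; within the scatter) and a 1.2-fold higher number from compound 1 to compound 4 (0.09 log units; within the scatter). The flat picture among the three substituted or unsubstituted phenyl compounds therefore extends to an exchange of the ring itself, and phenyl, 4-chlorophenyl, 4-(dimethylamino)phenyl and 5-methylfuran-2-yl are not told apart at this position. No supporting data bear on this result.

On these data alone, all four compounds carry an aromatic ring here, so it stays open whether a piperidine or a carboxylic acid at this place would move the number beyond the scatter. As far as these compounds go, whether a longer alkoxy chain in place of the methoxy group would do so also remains open.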